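A few compounds are considered here, and "the series" means these few. Any claim that something is new, unique, unknown or untested is made for them only; others in the source may bear on it.

Going by the values given here, compound 3 `O=C(CCCCCN1CCN(c2noc3ccccc23)CC1)NC1CCCc2ccccc21` is one of three compounds measured in an assay on HEK293 cells for displacement of a labelled ligand from 5-hydroxytryptamine receptor 7 (Rattus norvegicus) (a lower number here means a stronger inhibitor, a higher number a weaker inhibitor), where compound 3 gives 125 nM. Its number lies close to those of its two companions: compound 1 `COc1ccccc1N1CCN(CCCC(=O)NC2CCCc3cccc(OC)c32)CC1` gives 154 nM, and compound 2 `COc1ccccc1N1CCN(CCCC(=O)NC2CCCc3ccccc32)CC1` gives 92 nM; both gaps to compound 3 fall within the scatter of repeated measurements. Among the compounds with values here, the one measured step between neighbours, a 1.7-fold lower number from compound 1 to compound 2 (0.22 log units; within the scatter), replaces a methoxy with a hydrogen on an aromatic carbon and also stays within the scatter.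

Compound 4 `NC(=O)c1ccccc1N1CCN(CCCCCC(=O)NC2CCCc3ccccc32)CC1` differs from compound 3 in one place: a group of 9 heavy atoms (7 carbon, 1 nitrogen, 1 oxygen; one six-membered aromatic ring of carbon only) in place of a group of 9 heavy atoms (7 carbon, 1 nitrogen, 1 oxygen; one five-membered aromatic ring with 2 hetero atoms, one six-membered aromatic ring of carbon only), on an amine nitrogen in a ring. Within the data shown here, no measured pair changes the group on that ring nitrogen, so that single step bears on it only loosely, showing that one change elsewhere in the shared core left the number where it was. Among the measured compounds shown here, with the only measured step within the scatter, a change of no more than the scatter is expected here too, in no clear direction. Compound 4 is therefore expected to give about 150 nM in this assay, within a range from 50 nM to 450 nM. That estimate means an expected step of a 1.2-fold higher number from compound 3 to compound 4 (0.08 log units; within the scatter), staying within the scatter.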

Compound 4, inhibition constant: 229 nM
The estimate for compound 4 lay 1.5-fold (0.18 log units) below the measured number; the range from low to high includes it.
By their numbers in this assay, from the lowest: compounds 2, 3, 1 and 4 (each within the scatter of the next, the first and the last beyond it).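

In this assay, going by these compounds alone, this is the first measured change to the group on the ring nitrogen, since the earlier step altered only a methoxy on the other side of the molecule. Replacing the group with a five-membered aromatic ring and a fused six-membered ring by 2-carbamoylphenyl, which has a single six-membered aromatic ring and gains a hydrogen-bond donor, gives a 1.8-fold higher number from compound 3 to compound 4 (0.26 log units; within the scatter), so this pair shows no clear effect of the exchange. The data offer no measured explanation for how these two different groups come to give numbers within the scatter of each other.

From the compounds shown here alone, it remains open whether this tolerance extends to quite different groups on the same nitrogen, such as a plain phenyl, a 2-methoxyphenyl or a phenyl carrying a carboxylic acid or an amine in place of the carbamoyl group. The part played by the chain linking the ring to the amide also stays unresolved, as compound 2 and compound 4 differ in that chain and in the group on the ring nitrogen, so the two changes cannot be separated.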